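The source may report more compounds than this note shows. Statements on the series, on what has been measured and on what is new or still open speak of the compounds shown alone.

Working notes on the series. Three compounds carry measured numbers in a functional assay on MDA-MB-231 cells (Homo sapiens) for inhibition, read by MTT assay, with a stated time of 72 h, tested at 20 uM; on this read-out lower numbers stand for less inhibition and higher numbers for more inhibition at the one concentration tested (going by the name of the read-out). Compound 1 `c1cc(N2CCCCC2)nc(Nc2ccc(Oc3ncnc4sccc34)cc2)n1` gives 40.4%, compound 2 `CN(c1ccc(Oc2ncnc3ccsc23)cc1)c1nccc(N2CCCCC2)n1` gives 49.7%, and compound 3 `c1ccc2c(c1)CCN(c1ccnc(Nc3ccc(Oc4ncnc5ccsc45)cc3)n1)C2` gives 15.4%. Compound 3 stands lowest of the three; its gap to compound 1 and its gap to compound 2 both lie beyond the usual scatter, so compound 3 has the lowest inhibition in this assay measured so far.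

Compound 4 `c1cc(N2CCCCC2)nc(Nc2ccc(Oc3ncnc4ccsc34)cc2)n1` is the next structure to be run. Relative to compound 3 the change is piperidin-1-yl in place of 1,2,3,4-tetrahydroisoquinolin-2-yl on an aromatic carbon. Within the data shown here, the piperidin-1-yl group is the one found in compound 1 and compound 2, both of which sit well above compound 3, so the step of a number 24.6 percentage points higher from compound 3 to compound 4 (beyond the scatter) is expected to be upward and beyond the scatter. Compound 4 is estimated at 40%, with a likely range of 25% to 55%.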

Compound 4, a percentage reported as inhibition, at one concentration (the size of the read-out at that concentration, not a potency): 45.7%
The estimate for compound 4 lay 5.7 percentage points below the measured number, and the stated range covers the measured number.
By their numbers in this assay, from the lowest: compound 3; then compounds 1, 4 and 2 (each within the scatter of the next).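

In this assay, among these compounds, a number 30.3 percentage points higher from compound 3 to compound 4 (beyond the scatter) gives the first direct reading at this position: with piperidin-1-yl in place of 1,2,3,4-tetrahydroisoquinolin-2-yl on the aromatic carbon, the low number of compound 3 goes with the larger group. Two other changes stay within the scatter: a number 4 percentage points lower from compound 2 to compound 4 (within the scatter) for methyl on the nitrogen, and a number 5.3 percentage points higher from compound 1 to compound 4 (within the scatter) for the exchange of the group on the oxygen. No measured evidence accounts for these results. Open, on these data alone, is how morpholin-4-yl or an open-chain group such as dimethylamino would read at this carbon.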